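This account rests on a few compounds, and the source may have more. Where it says the series, first, only, none or still open, it means among the compounds named here.

Within the data shown here, in a functional assay on PC-3 cells (Homo sapiens) for cytotoxicity, read by MTT assay, with a stated time of 48 h (on this read-out lower numbers stand for stronger inhibition and higher numbers for weaker inhibition), compound 3 `C=CC[C@@H](OC(=O)C=C)c1cccc2ccccc12` gives 22900 nM, the highest of the three numbers so far and the weakest inhibition, beyond the scatter from both other compounds: compound 1 `O=C1C=CC[C@H](c2cnc3ccccc3c2)O1` gives 2500 nM and compound 2 `Cc1ccc([C@H]2CC=CC(=O)O2)c2ccccc12` gives 50 nM. Compound 4 `C=CC[C@@H](OC(=O)C=C)c1c(C)ccc2ccccc12` differs from compound 3 by a single change, (methyl in place of hydrogen on an aromatic carbon), methyl in place of hydrogen on an aromatic carbon. Among the measured compounds shown here, no measured pair isolates this change, so the expectation rests on little. A small step towards a lower number is expected in this assay, possibly none beyond the scatter. The estimated value for compound 4 is 14000 nM, with an expected range of 5000 nM to 35000 nM.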

Compound 4, half-maximal inhibitory concentration: 8800 nM
Compound 4: the middle estimate sits 1.6-fold (0.20 log units) above what was measured, and the stated range covers the measured number.
By their numbers in this assay, from the lowest: compound 2; then compound 1; then compound 4; then compound 3.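

In this assay, among these compounds, methyl in place of hydrogen on an aromatic carbon, ortho to a group of 9 heavy atoms, gives a 2.6-fold lower number from compound 3 to compound 4 (0.42 log units; beyond the scatter) and so provides the first single-change step. One added carbon at this place is enough to move the number beyond the scatter, so this position is not silent on this read-out. Nothing on hand bears on why the number moves.

Going by these compounds, whether an amine, a methoxy group or a longer chain at this place would give a larger step, a smaller one or a reversal stays open. Also open, on these data alone, is whether methyl gives a similar step elsewhere on the same ring.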